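Swapping the aniline partner on a sulfonyl quinoxaline core

A few compounds are considered here, and "the series" means these few. Any claim that something is new, unique, unknown or untested is made for them only; others in the source may bear on it.

Compound 1, `O=S(=O)(c1ccccc1)c1nc2ccccc2nc1Nc1ccc(F)cc1`, is the parent of this small set. In a functional assay on KB cells (Homo sapiens) for cytotoxicity, read by MTT assay, with a stated time of 72 h (on this read-out higher numbers stand for weaker inhibition and lower numbers for stronger inhibition), compound 1 gives only a limit, > 50000 nM, so no number is known for it. Within the data shown here, compound 2, `Cc1ccc(S(=O)(=O)c2nc3ccccc3nc2Nc2ccc(F)cc2)cc1`, carries a methyl in place of hydrogen on an aromatic carbon, and in this assay compound 2 gives 8950 nM; the step of an at least 5.5-fold lower number from compound 1 to compound 2 (0.74 log units; beyond the scatter) is the single measured step here, and it rests on (the limit of > 50000 nM in this assay, at which 1 of the 3 values shown sits). Among the measured compounds shown here, compound 3, `COc1ccc(S(=O)(=O)c2nc3ccccc3nc2Nc2cccc(N)c2)cc1`, differs from compound 2 in more than one place, so no single step connects them; in this assay compound 3 gives 4960 nM, which cannot be told apart from the number for compound 2 within the usual scatter.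

Compound 4, `COc1ccc(S(=O)(=O)c2nc3ccccc3nc2Nc2ccc(F)cc2)cc1`, is obtained from compound 3 by 4-fluorophenyl in place of 3-aminophenyl on a nitrogen on an aromatic ring. For the measured compounds named here, the only measured step concerns a different part of the shared core, so nothing measured bears directly on this change. Compound 4 is therefore expected to stay close to compound 3, with an estimated 1.4-fold higher number from compound 3 to compound 4 (0.15 log units; within the scatter) that does not go beyond the scatter. In this assay compound 4 is estimated at 7000 nM, within a range from 2000 nM to 25000 nM.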

Compound 4, half-maximal inhibitory concentration: 2590 nM
Beside the measured number, compound 4's estimate is 2.7-fold (0.43 log units) above it; the range from low to high includes it.
By their numbers in this assay, from the lowest: compounds 4, 3 and 2 (each within the scatter of the next, the first and the last beyond it). At a limit, above all of these: compound 1.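

Among these compounds, compound 4 gives the first single-change look at the aniline partner, and in this assay 4-fluorophenyl in place of 3-aminophenyl on the nitrogen makes no difference that can be told from the scatter (a 1.9-fold lower number from compound 3 to compound 4 (0.28 log units; within the scatter)). The change that does register lies on the other aryl group, where, with 4-fluorophenyl held fixed, methoxy on an aromatic carbon gives a lower number than methyl (a 3.5-fold lower number from compound 2 to compound 4 (0.54 log units; beyond the scatter)) and a far lower one than hydrogen (an at least 19-fold lower number from compound 1 to compound 4 (1.28 log units; beyond the scatter)). The size of this last step is only a minimum, since compound 1 has a limit and no number, and it rests on that one limit: (the limit of > 50000 nM in this assay, at which 1 of the 4 values shown sits).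

The compounds shown leave open whether the falling numbers from hydrogen through methyl to methoxy would continue with an ethoxy group or a chlorine atom on that same carbon. They also leave open how the aniline partner responds to other groups, such as 4-aminophenyl or 3-fluorophenyl, which would help show whether the kind of group or its place on the ring matters more.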